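Chain-extended hydroxamates on a coumarin-derived and a phenol-derived core

A few compounds are considered here, and "the series" means these few. Any claim that something is new, unique, unknown or untested is made for them only; others in the source may bear on it.

Of the compounds shown here, three have been measured in a functional assay on Hep 3B2 cells (Homo sapiens) for antiproliferative activity, read by sulforhodamine B assay, with a stated time of 48 h; on this read-out lower numbers stand for stronger inhibition of growth and higher numbers for weaker inhibition of growth. Compound 1 `CC(C)CCc1c(OCCCCCCCC(=O)NO)ccc2ccc(=O)oc12` gives 3580 nM, and compound 2 `CC(C)CCc1c(OCCCCCCC(=O)NO)ccc2ccc(=O)oc12` gives 750 nM. The step of a 4.8-fold higher number from compound 2 to compound 1 (0.68 log units; beyond the scatter) follows from (hydroxycarbamoyl)methyl in place of hydroxycarbamoyl on a saturated chain carbon, six bonds along the chain from an oxygen on an aromatic ring. Compound 3 `CC(C)CCc1c(OCCCCC(=O)NO)ccc(CCC(=O)NO)c1O` gives 14100 nM, the highest number of the three; the difference between its core and the core of compound 2 is not broken down here, so of that pair only the two values can be compared.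

Compound 4 `CC(C)CCc1c(OCCCCCC(=O)NO)ccc(CCC(=O)NO)c1O` has not been measured in this assay. It differs from compound 3 by (hydroxycarbamoyl)methyl in place of hydroxycarbamoyl on a saturated chain carbon, four bonds along the chain from an oxygen on an aromatic ring. For the measured compounds named here, this is the same kind of change as the one from compound 2 to compound 1, but not the same: there the place was six bonds along the chain from an oxygen on an aromatic ring, here it is four bonds along the chain from that oxygen, and the cores differ.

Going by the values given here, because the single measured example of this change, a 4.8-fold higher number from compound 2 to compound 1 (0.68 log units; beyond the scatter), went toward a weaker inhibition of growth, a step in the same direction is expected for compound 4, though with a shorter chain and a different core the size is uncertain. Compound 4 is estimated to give 25000 nM, between 8000 nM and 90000 nM, which is expected to mean a 1.8-fold higher number from compound 3 to compound 4 (0.25 log units; within the scatter).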

Compound 4, concentration for 50% growth inhibition: 1980 nM
Compound 4: middle estimate off by 13-fold (1.10 log units), on the high side; measured number outside the range, below it.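

In this assay, the change from hydroxycarbamoyl to (hydroxycarbamoyl)methyl gives a 7.1-fold lower number from compound 3 to compound 4 (0.85 log units; beyond the scatter). Set beside the earlier step, the same change does not carry over from one core to the other, in direction or in size: the same change on two cores in this assay, a 4.8-fold higher number (0.68 log units; beyond the scatter) from compound 2 to compound 1 and a 7.1-fold lower number (0.85 log units; beyond the scatter) from compound 3 to compound 4, 34-fold (1.53 log units) apart, beyond the scatter of two such steps

This shows that, among these compounds, the outcome of the change on one core cannot be used to predict its outcome on the other. It does not show why the steps part, for they differ both in the core and in the place of the change, four bonds along the chain from an oxygen on an aromatic ring in one case and six in the other, and each direction rests on a single pair.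

The compounds shown leave open how the numbers would move with a shorter or a longer chain on either core, and so whether either pair reflects a wider trend. They also leave open whether a carboxylic acid in place of the hydroxycarbamoyl group would retain any inhibition of growth.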